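Shifting a Ring Substituent from Methyl to Chloro

The source may hold more compounds than are shown below. What is called first, only, known or untested is meant among the compounds shown, and "the series" means these compounds.

Compound 1 `Cc1cccc(CSc2cc(Cl)c(C)cc2S(=O)(=O)/N=C(\N)n2nccc2-c2ccccc2)c1` gives 47000 nM in a functional assay on MCF7 cells (Homo sapiens) for cytotoxicity, read by MTT assay, with a stated time of 72 h; a lower number here means a stronger inhibitor, a higher number a weaker inhibitor. Compound 2 `Cc1ccc(CSc2cc(Cl)c(C)cc2S(=O)(=O)/N=C(\N)n2nccc2-c2ccccc2)cc1` gives 21000 nM in this assay; it is the positional isomer of compound 1, and the step of a 2.2-fold lower number from compound 1 to compound 2 (0.35 log units; beyond the scatter) is modest. Within the data shown here, on the two numbers known, compound 2 stands lowest, with compound 1 as its only neighbour.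

Compound 3 `Cc1cc(S(=O)(=O)/N=C(\N)n2nccc2-c2ccccc2)c(SCc2ccc(Cl)cc2)cc1Cl` is the next compound to be measured. It differs from compound 2 by chloro in place of methyl on an aromatic carbon. Among the measured compounds shown here, no measured step exchanges methyl for chloro; the only step known, from compound 1 to compound 2, moves a methyl on the same ring and is modest in size. It therefore gives no direction for this exchange, and a step of about that size either way, or none beyond the scatter, is expected. Compound 3 is estimated at 21000 nM, within 8000 nM to 55000 nM, a step of no change at the digits printed from compound 2 to compound 3 (within the scatter) from compound 2.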

Compound 3, half-maximal inhibitory concentration: 75000 nM
Compound 3: the middle estimate sits 3.6-fold (0.55 log units) below what was measured, and the stated range ends below it.
By their numbers in this assay, from the lowest: compound 2; then compounds 1 and 3 (each within the scatter of the next).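

In this assay the exchange of methyl for chloro at this place, para to a large group, is not neutral: a 3.6-fold higher number from compound 2 to compound 3 (0.55 log units; beyond the scatter) shows that the 4-methylbenzyl group of compound 2 cannot be swapped for 4-chlorobenzyl without a loss. With a 1.6-fold higher number from compound 1 to compound 3 (0.20 log units; within the scatter) as the other reading, the 4-chlorophenyl and 3-methylphenyl ends are not separated, so compound 2 alone stands apart from the other two. Nothing on hand accounts for this difference.

As far as these compounds go, whether a methoxy group, an ethyl group or an amine at this place would stay with compound 2 or fall with compound 3 remains open. So does whether methyl and chloro would rank the same way on a core other than the one shared here.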